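The compounds below may be only part of what the source reports. "The series", "measured", "known", "first", "only" and "open" are said of these compounds alone.

Of the compounds shown here, three built on one shared core have been tested so far. Compound 1 `Cc1nnc(SCC(=O)N/N=c2/scc(-c3ccccc3)n2-c2ccccc2)s1` gives, in a functional assay on C6 cells (Rattus norvegicus) for cytotoxicity, read by MTT assay, with a stated time of 24 h, tested at 6 ug/mL (a lower number here means a stronger effect, a higher number a weaker effect of the compound at the concentration tested), a value of 72.4%. Compound 2 `Cc1ccc(-c2cs/c(=N/NC(=O)CSc3nnnn3C)n2-c2ccccc2)cc1` gives in this assay a value of 88%. Compound 3 `O=C(CSc1nnnn1-c1ccccc1)N/N=c1/scc(-c2ccccc2)n1-c1ccccc1` gives in this assay a value of 52.1%, the lowest of the three and thus the strongest effect in this small set. For the measured compounds named here, the only single-change comparison among them runs from compound 1 to compound 3, where the change on the sulfur brought a number 20.3 percentage points lower from compound 1 to compound 3 (beyond the scatter).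

The next compound, compound 4 `Cn1nnnc1SCC(=O)N/N=c1/scc(-c2ccccc2)n1-c1ccccc1`, differs from compound 3 in one place: methyl in place of phenyl on an aromatic nitrogen. Going by the values given here, no measured pair isolates this exact change. Compound 2 does carry the same methyl-bearing tetrazole, but it also differs from compound 3 elsewhere, so the comparison is only a hint: compound 3 gives 52.1%, whereas compound 2 gives the higher 88%. Taken as a hint, it suggests a weaker effect, so a moderate upward step a number 17.9 percentage points higher from compound 3 to compound 4 (beyond the scatter) is expected. Compound 4 is therefore estimated at 70%, with a likely range from 52% to 88%.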

Compound 4, a percentage reported as activity, at one concentration (the size of the read-out at that concentration, not a potency): 85.2%
Compound 4: middle estimate off by 15.2 percentage points, on the low side; the range from low to high includes it.
By their numbers in this assay, from the lowest: compound 3; then compound 1; then compounds 4 and 2 (each within the scatter of the next).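

The phenyl on this aromatic nitrogen of the tetrazole matters far more than the opening hint suggested: replacing it with methyl gives a number 33.1 percentage points higher from compound 3 to compound 4 (beyond the scatter) in this assay, so most of the effect seen with the 1-phenyl-1H-tetrazol-5-yl group is lost. The tetrazole alone therefore does not confer the stronger effect, since the 1-methyl-1H-tetrazol-5-yl group compares unfavourably with the 5-methyl-1,3,4-thiadiazol-2-yl group on the same sulfur, with a number 12.8 percentage points higher from compound 1 to compound 4 (beyond the scatter), while the methyl on an aromatic carbon elsewhere in the molecule makes no distinguishable difference, with a number 2.8 percentage points lower from compound 2 to compound 4 (within the scatter). Nothing available explains why the phenyl has this effect on the read-out.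

Going by these compounds, it remains open whether the aromatic ring itself is needed or whether any larger group on this nitrogen would do, a question that an ethyl group, a longer chain such as n-butyl or a saturated cyclohexyl ring could help settle. A phenyl carrying a chlorine or a methoxy group could also show whether the effect can be pushed further than in compound 3, which gives 52.1%.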